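This account rests on a few compounds, and the source may have more. Where it says the series, first, only, none or still open, it means among the compounds named here.

Compound 1 `CCOC(=O)C1CCN(C(=O)CN2CN(c3ccccc3)C3(CCN(C(=O)c4ccc(C5CCCCC5)cc4)CC3)C2=O)CC1` is measured in an assay on HEK293 cells for displacement of a labelled ligand from NPC1-like intracellular cholesterol transporter 1 (Homo sapiens); a lower number here means a stronger inhibitor, a higher number a weaker inhibitor. There compound 1 gives 900 nM. That is the lowest of the two numbers available. Among the compounds with values here, compound 2 `CCOC(=O)C1CCN(C(=O)CN2CN(c3ccccc3)C3(CCN(C(=O)c4ccc(C(C)(C)C)cc4)CC3)C2=O)CC1` gives 3100 nM in this assay; the one change between them, tert-butyl in place of cyclohexyl on an aromatic carbon, brings a 3.4-fold higher number from compound 1 to compound 2 (0.54 log units; beyond the scatter). Compound 3 `CCc1nn(CC)c(C2CCN(C(=O)CN3CN(c4ccccc4)C4(CCN(C(=O)c5ccc(C6CCCCC6)cc5)CC4)C3=O)CC2)c1C` has no result in this assay: for compound 3 the entry reads "not determined" (no result reported). Compound 4 `CC(C)(C)OC(=O)NCNC(=O)CN1CN(c2ccccc2)C2(CCN(C(=O)c3ccc(C4CCCCC4)cc3)CC2)C1=O` differs from compound 1 in another part of the molecule: (((tert-butoxycarbonyl)amino)methyl)amino in place of 4-(ethoxycarbonyl)piperidin-1-yl on a carbonyl carbon. Within the data shown here, no measured step touches that part. Among the measured compounds shown here, the only step known, a 3.4-fold higher number from compound 1 to compound 2 (0.54 log units; beyond the scatter), concerns the aromatic substituent and therefore says nothing about swapping the group on the carbonyl carbon. With nothing to lean on, no step beyond the scatter is expected in either direction, but the range has to stay wide to cover the uncertainty of an untested change. Compound 4 is therefore estimated at 1500 nM, within a range from 400 nM to 6000 nM. The step this estimate expects is a 1.7-fold higher number from compound 1 to compound 4 (0.22 log units; within the scatter).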

Compound 4, half-maximal inhibitory concentration: 1700 nM
The estimate for compound 4 lay 1.1-fold (0.05 log units) below the measured number; low and high end bracket the measured number.
By their numbers in this assay, from the lowest: compounds 1, 4 and 2 (each within the scatter of the next, the first and the last beyond it).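

Among the earlier compounds with a number, the group on the carbonyl carbon stayed the same; replacing it gives a 1.9-fold higher number from compound 1 to compound 4 (0.28 log units; within the scatter) in this assay. So in this pair, 4-(ethoxycarbonyl)piperidin-1-yl, with its six-membered ring and 0 hydrogen-bond donors, gives way to the ring-free (((tert-butoxycarbonyl)amino)methyl)amino, with 2 hydrogen-bond donors, and the step stays within the scatter. No measurement is available that would explain this result.

This single pair changes the ring and the hydrogen-bond donors together, so it cannot show whether either matters on its own. It also leaves open whether a carboxylic acid in place of the ethyl ester, or a simple primary amine on the carbonyl carbon, would give a number in the same range.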